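The source may report more compounds than this note shows. Statements on the series, on what has been measured and on what is new or still open speak of the compounds shown alone.

Series notes on the thiazole acetic acids.

Compound 1 `N#Cc1cc(-c2nc(C(c3ccc(F)cc3)c3ccc(F)cc3)sc2CC(=O)O)ccc1F` is the reference point here. In an in vitro functional assay on HEK285-7 cells for antagonist activity at prostaglandin D2 receptor 2 (Homo sapiens), read by BRET and beta-arrestin recruitment (a higher number here means a larger maximal response, a lower number a smaller maximal response), compound 1 gives 80%. Compound 2 `COc1ccc(C(c2ccccc2)c2nc(-c3ccc(Cl)cc3)c(CC(=O)O)s2)cc1` gives 80% in this assay, and compound 3 `O=C(O)Cc1sc(C(c2ccccc2)c2ccc(O)cc2)nc1-c1ccc(F)cc1` gives 80%. Compound 1 thus stands level with compound 2 and compound 3 at the digits shown; the gaps to both lie within the scatter, so no ordering among the three can be read from these numbers.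

Compound 4 `Nc1cc(-c2nc(C(c3ccc(F)cc3)c3ccc(F)cc3)sc2CC(=O)O)cc(F)n1` is not yet measured. It differs from compound 1 in one place: 2-amino-6-fluoropyridin-4-yl in place of 3-cyano-4-fluorophenyl on an aromatic carbon. Within the data shown here, no measured pair in the set isolates a change of this kind, so nothing in the data points to a shift in maximal response in either direction. The working expectation is therefore no change beyond the scatter, a step of no change at the digits printed from compound 1 to compound 4 (within the scatter). For compound 4 the estimated maximal response is 80%, expected to fall between 65% and 92%.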

Compound 4, largest response reached (reported as efficacy), in percent of the reference or control that the assay uses: 30%
Compound 4: the middle estimate sits 50 percentage points above what was measured; the measured number lies below the stated range.
By their numbers in this assay, from the lowest: compound 4; then compounds 1, 2 and 3 (each within the scatter of the next).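

In this assay, 2-amino-6-fluoropyridin-4-yl in place of 3-cyano-4-fluorophenyl gives a number 50 percentage points lower from compound 1 to compound 4 (beyond the scatter). Among these compounds, this is the first single-place change, and it shows that the maximal response depends on the group at this aromatic carbon next to the ring nitrogen. Nothing at hand bears on the reason for this step.

Going by these compounds, the nitrile leaves while an amine and a ring nitrogen enter, so the part of the change that carries the step stays open. On these data alone, whether 2-aminopyridin-4-yl or 3-cyanophenyl at this position would keep the response of compound 1 also remains open.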